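A Furan in Place of a Methylphenyl Group

A few compounds are considered here, and "the series" means these few. Any claim that something is new, unique, unknown or untested is made for them only; others in the source may bear on it.

The shared core carries two groups on a nitrogen that also bears a thiocarbonyl. Compound 1 `Cc1ccc(C(=O)N(C(=S)OCCN2C(=O)c3ccccc3C2=O)c2ccc(Cl)cc2)cc1` is the starting point. In an ADME assay on MT4 cells (Homo sapiens) for cytotoxicity, read by MTT assay (a higher number here means that more compound is tolerated, a lower number that less compound is tolerated), compound 1 gives > 100000 nM, which is a limit of the assay rather than a measured number. Compound 2 `O=C1c2ccccc2C(=O)N1CCOC(=S)N(C(=O)c1cccnc1Cl)c1ccc(Br)cc1` also reaches only a limit, giving > 100000 nM in this assay. Compound 3 `O=C1c2ccccc2C(=O)N1CCOC(=S)N(C(=O)c1ccc(F)c(F)c1)c1ccc(Cl)cc1`, carrying a 3,4-difluorophenyl in place of the 4-methylphenyl, gives 52000 nM. Going by the values given here, that exchange is the one measured step, an at least 1.9-fold lower number from compound 1 to compound 3 (0.28 log units; that floor lies within the scatter); it starts from a limit since (the limit of > 100000 nM in this assay, at which 2 of the 3 values shown sit), so only a floor for its size is known, and that floor lies within the scatter.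

Compound 4 `Cc1cc(C(=O)N(C(=S)OCCN2C(=O)c3ccccc3C2=O)c2ccc(Cl)cc2)c(C)o1` differs from compound 1 by 2,5-dimethylfuran-3-yl in place of 4-methylphenyl on a carbonyl carbon. Among the compounds with values here, this is again an exchange of the group on the carbonyl carbon, and the only comparable step gave no change beyond the scatter. For compound 4 the number is therefore expected to stay close to that of compound 1, a step of a number no higher from compound 1 to compound 4 (the limit leaves the size open), with the estimate 100000 nM spanning 40000 nM to 250000 nM.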

Compound 4, half-maximal cytotoxic concentration: 40000 nM
Beside the measured number, compound 4's estimate is 2.5-fold (0.40 log units) above it; the range from low to high includes it.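

In this assay, going by these compounds alone, the exchange on the carbonyl carbon now shows an at least 2.5-fold lower number from compound 1 to compound 4 (0.39 log units; beyond the scatter) and is the first step at this position to clear the scatter. Measured against the other replacement group, a 1.3-fold lower number from compound 3 to compound 4 (0.11 log units; within the scatter) shows that 2,5-dimethylfuran-3-yl and 3,4-difluorophenyl on this carbonyl carbon give numbers that cannot be told apart. From the compounds shown here alone, the full size of the step from compound 1 stays unknown, since compound 1 stands at a limit of the assay: the limit of > 100000 nM in this assay, at which 2 of the 4 values shown sit.

Going by these compounds, it remains open whether the furan ring itself or its two methyl groups account for the step, a question that a furan-3-yl without methyl groups could help to settle. Also open, on these data alone, is how a cyclohexyl group, or an aromatic ring carrying an amine, on the same carbonyl carbon would read in this assay.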